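Aryl amide swaps and growth inhibition at one concentration

The source may report more compounds than this note shows. Statements on the series, on what has been measured and on what is new or still open speak of the compounds shown alone.

Measured so far in a functional assay on A549 cells (Homo sapiens) for inhibition, read by CCK-8 assay, with a stated time of 72 h, tested at 10 uM; a lower number here means less inhibition of growth, a higher number more inhibition of growth at the concentration tested:
- compound 1 `CN(C)C(=O)c1cc2cnc(Nc3ccc(NC(=O)C4(C(=O)Nc5ccc(F)cc5)CC4)cc3)nc2n1C1CCCC1`: 102%
- compound 2 `COC(=O)c1ccc(NC(=O)C2(C(=O)Nc3ccc(Nc4ncc5cc(C(=O)N(C)C)n(C6CCCC6)c5n4)cc3)CC2)cc1`: 92%
- compound 3 `CN(C)C(=O)c1cc2cnc(Nc3ccc(NC(=O)C4(C(=O)Nc5ccc(Cl)c(C(F)(F)F)c5)CC4)cc3)nc2n1C1CCCC1`: 88.1%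

Compound 2, at 92%, cannot be separated from either of the other two compounds. The comparison with the first shows a number 10 percentage points lower from compound 1 to compound 2 (within the scatter), and the comparison with the third shows a number 3.9 percentage points lower from compound 2 to compound 3 (within the scatter).

The next compound is compound 4 `Cc1ccc(NC(=O)C2(C(=O)Nc3ccc(Nc4ncc5cc(C(=O)N(C)C)n(C6CCCC6)c5n4)cc3)CC2)cc1`, which has methyl in place of methoxycarbonyl on an aromatic carbon, para to a large group (methyl in place of methoxycarbonyl on an aromatic carbon). The rest of compound 2 is unchanged.

Two measured steps involve the same methoxycarbonyl-bearing ring: a number 10 percentage points lower from compound 1 to compound 2 (within the scatter), and a number 3.9 percentage points lower from compound 2 to compound 3 (within the scatter). Neither lies beyond the scatter. Within the data shown here, the only step that does is a number 13.9 percentage points lower from compound 1 to compound 3 (beyond the scatter), and it is modest. Among the measured compounds shown here, no measured compound carries the methyl group, so this expectation rests on three aryl variants only. In this assay, no step beyond the scatter is expected for this change, and the direction is left open.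

The expected step is a number 1 percentage points higher from compound 2 to compound 4 (within the scatter).

Compound 4 is estimated at 93%, with an expected range of 80% to 105%.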

Compound 4, percent growth inhibition at one concentration: 90.6%
Beside the measured number, compound 4's estimate is 2.4 percentage points above it, within the range that was stated.
By their numbers in this assay, from the lowest: compounds 3, 4, 2 and 1 (each within the scatter of the next, the first and the last beyond it).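

In this assay, the exchange of methoxycarbonyl for methyl on this aromatic carbon, para to a large group, removes a double bond outside the aromatic rings and both hydrogen-bond acceptors of that group, yet gives a number 1.4 percentage points lower from compound 2 to compound 4 (within the scatter). The 4-methylphenyl amide also cannot be separated from the 4-chloro-3-(trifluoromethyl)phenyl amide, with a number 2.5 percentage points higher from compound 3 to compound 4 (within the scatter), so a small group carrying no acceptor stands with the larger aryl variants at this concentration. Against the 4-fluorophenyl amide there is a number 11.4 percentage points lower from compound 1 to compound 4 (beyond the scatter), a second modest step beyond the scatter alongside a number 13.9 percentage points lower from compound 1 to compound 3 (beyond the scatter), but compound 2 goes against any reading of compound 1 as apart from all the others, with a number 10 percentage points lower from compound 1 to compound 2 (within the scatter).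

No evidence is available to explain these numbers. Open, going by these compounds, is whether an amine, a carboxylic acid or a longer alkyl chain on this aromatic carbon would stay with these compounds or give a step beyond the scatter from compound 4.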